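The source may hold more compounds than are shown below. What is called first, only, known or untested is meant among the compounds shown, and "the series" means these compounds.

Measured in a physicochemical assay for acid dissociation:

- compound 1 `CCCCCCS(=O)(=O)c1ccc(O)c(C(=O)Nc2ccc(Br)cc2)c1`: 5.2
- compound 2 `CCCCCCCCS(=O)(=O)c1ccc(O)c(C(=O)Nc2ccc(C(F)(F)F)cc2)c1`: 6.2
- compound 3 `CS(=O)(=O)c1ccc(O)c(C(=O)Nc2ccc(C(F)(F)F)cc2)c1`: 6.2

Among these three, compound 1, at 5.2, has the lowest number, and both compound 2 and compound 3 lie higher, beyond the scatter. The next compound to be examined in this assay is compound 4 `CCCCCCCCCCCCS(=O)(=O)c1ccc(O)c(C(=O)Nc2ccc(Br)cc2)c1`, which differs from compound 1 by a single change: hexyl in place of hydrogen on a saturated chain carbon, six bonds along the chain from a sulfonyl sulfur.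

For the measured compounds named here, one measured step bears on this change. It also alters only the chain on the sulfonyl sulfur: no change at the digits printed from compound 2 to compound 3 (within the scatter). Going by the values given here, there, hydrogen takes the place of heptyl on a saturated chain carbon bound to a sulfonyl sulfur, so the change sits at a different carbon from the one in compound 4. Among the compounds with values here, that step also comes from compounds carrying trifluoromethyl where compound 1 carries bromine, and no measured pair tests a chain change on the bromine-bearing compounds. The evidence is therefore indirect, but it gives no reason to expect a shift in either direction.

The expected result is no change at the digits printed from compound 1 to compound 4 (within the scatter), meaning no change beyond the scatter. For compound 4 the estimated value is 5.2, with an expected range from 4.8 to 5.6.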

Compound 4, acid dissociation constant: 5.2
For compound 4 middle estimate and measured number coincide at the digits printed; the range from low to high includes it.
By their numbers in this assay, from the lowest: compounds 1 and 4 (each within the scatter of the next); then compounds 2 and 3 (each within the scatter of the next).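

In this assay, the bromine-bearing compounds now give a direct reading of a chain change: there is no change at the digits printed from compound 1 to compound 4 (within the scatter), with hexyl in place of hydrogen on a saturated chain carbon, six bonds along the chain from a sulfonyl sulfur. The only earlier chain step came from the trifluoromethyl-bearing compounds, with no change at the digits printed from compound 2 to compound 3 (within the scatter), so among the compounds shown, both chain steps, made at different carbons and with different groups on the far ring of the core, stay within the scatter, and none goes against this. Nothing given here explains why the longer chain leaves the number where it is.

The compounds shown leave open whether the reading would hold if the sulfonyl sulfur carried a chain ending in a carboxylic acid or an amine, or a phenyl ring in place of a saturated chain. They also leave open how much of the distance between the bromine-bearing and trifluoromethyl-bearing compounds belongs to that one group, since no pair shown differs in that place alone.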